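This account rests on a few compounds, and the source may have more. Where it says the series, first, only, none or still open, it means among the compounds named here.

Compounds measured in an assay for inhibition of 6-phosphofructo-2-kinase/fructose-2,6-bisphosphatase 3 (Homo sapiens), read by ADP-Glo, with a stated time of 2 h; on this read-out lower numbers stand for stronger inhibition and higher numbers for weaker inhibition:
compound 1 `Cn1ccc2ccc(-c3cc(Nc4ccccc4S(N)(=O)=O)cc4nccnc34)cc21`: 265 nM
compound 2 `CN1CCC(NS(=O)(=O)c2ccccc2Nc2cc(-c3ccc4ccn(C)c4c3)c3nccnc3c2)C1`: 33 nM
compound 3 `CN(C)C(=O)c1ccncc1Nc1cc(-c2ccc3ccn(C)c3c2)c2nccnc2c1`: 499 nM

Compound 3 gives the highest of the three numbers, though its gap to compound 1 lies within the scatter, while compound 2 stands well below it. Compound 4 `CN1CCC(NC(=O)c2ccncc2Nc2cc(-c3ccc4ccn(C)c4c3)c3nccnc3c2)CC1=O` differs from compound 3 by (1-methyl-2-oxopiperidin-4-yl)amino in place of dimethylamino on a carbonyl carbon. Among the measured compounds shown here, the one measured step that bears on this change is an 8.0-fold lower number from compound 1 to compound 2 (0.90 log units; beyond the scatter), where a ring-bearing group replaced hydrogen on a sulfonamide nitrogen. Here the change sits on a carbonyl carbon, the group replaced is dimethylamino rather than hydrogen, and the entering ring carries an oxo group, so a smaller gain is expected. The expected step is a 3.1-fold lower number from compound 3 to compound 4 (0.49 log units; beyond the scatter). Compound 4 is therefore estimated at 160 nM, within a range of 50 nM to 500 nM.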

Compound 4, half-maximal inhibitory concentration: 41 nM
Compound 4: the middle estimate sits 3.9-fold (0.59 log units) above what was measured, outside the stated range (below it).
By their numbers in this assay, from the lowest: compounds 2 and 4 (each within the scatter of the next); then compounds 1 and 3 (each within the scatter of the next).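

In this assay, replacing dimethylamino with (1-methyl-2-oxopiperidin-4-yl)amino on a carbonyl carbon gives a 12-fold lower number from compound 3 to compound 4 (1.09 log units; beyond the scatter). A ring-bearing group thus lowers the number at this place too, not only on a sulfonamide nitrogen, as in an 8.0-fold lower number from compound 1 to compound 2 (0.90 log units; beyond the scatter). Nothing measured here gives a reason for the new step.

The compounds shown leave open whether the step comes from the ring, its oxo group or the amide hydrogen. Methylamino or (1-methylpiperidin-4-yl)amino on the same carbonyl carbon would help to separate these parts.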